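A methyl on the ring nitrogen's neighbour, tried a second time

The source may hold more compounds than are shown below. What is called first, only, known or untested is meant among the compounds shown, and "the series" means these compounds.

Of the compounds shown here, three have so far been measured in a functional assay on the whole organism (strain Wistar Albino) for inhibition, with Rattus norvegicus as the target, read by paw edema, with a stated time of 4 h, at a dose of 20 mg/kg; a higher number here means more inhibition at the dose given (going by the name of the read-out), a lower number less inhibition. Compound 1, `Cc1cc(-c2nn3c(-c4ccoc4C)nnc3s2)c2ccccc2n1`, gives 26.3% in this assay. Compound 2, `Cc1occc1-c1nnc2sc(-c3ccnc4ccccc34)nn12`, gives 23.4% in this assay. Compound 3, `COc1ccc2[nH]cc(Cc3nn4c(Cc5ccc(OC)c(OC)c5)nnc4s3)c2c1`, gives 29.6% in this assay; the difference between its core and the core of compound 2 is not broken down here.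

Compound 2 and compound 1 differ in one place, (methyl in place of hydrogen on an aromatic carbon), and that step is a number 2.9 percentage points higher from compound 2 to compound 1 (within the scatter), so the two values are not told apart by this assay.

Compound 4, `COc1ccc2[nH]c(C)c(Cc3nn4c(Cc5ccc(OC)c(OC)c5)nnc4s3)c2c1`, has not yet been measured. It differs from compound 3 in one place, (methyl in place of hydrogen on an aromatic carbon). For the measured compounds named here, this is the same kind of change as the one from compound 2 to compound 1, but not the same: there the methyl entered on an aromatic carbon of a six-membered aromatic ring with 1 nitrogen, while here it enters on an aromatic carbon of a five-membered aromatic ring with 1 nitrogen, next to the ring atom that bears a large group.

Because the earlier step was a number 2.9 percentage points higher from compound 2 to compound 1 (within the scatter), the step from compound 3 to compound 4 in this assay is expected to be a number 1.4 percentage points higher from compound 3 to compound 4 (within the scatter), small and within the scatter. Compound 4 is therefore estimated to give about 31% in this assay, with a range from 22% to 40%.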

Compound 4, a percentage reported as inhibition, in the whole organism at one dose (the size of the read-out at that dose, not a potency): 28.4%
Beside the measured number, compound 4's estimate is 2.6 percentage points above it, and the stated range covers the measured number.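

Read in this assay, the methyl in place of hydrogen on an aromatic carbon comes out as a number 1.2 percentage points lower from compound 3 to compound 4 (within the scatter), so this assay does not tell the two values apart. Set beside the earlier case, the step on the new core does not differ from the one on the first core: the same change on two cores in this assay, a number 2.9 percentage points higher (within the scatter) from compound 2 to compound 1 and a number 1.2 percentage points lower (within the scatter) from compound 3 to compound 4, 4.1 percentage points apart, within the scatter of two such steps. This shows that on both cores the change leaves the inhibition of paw edema at the dose given within the usual spread of repeated measurements, and that nothing in these two pairs marks one core as responding differently from the other; it does not show that the change has no effect at all, nor does it fix the direction of any small effect, since the two steps have opposite signs and neither can be read as real.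

The compounds shown carry only hydrogen or methyl at the two changed places, so what an amine, a carboxylic acid or a longer chain would do on that aromatic carbon of either core stays open. Also open, on these data alone, is whether the same two pairs would stay as close at other doses or at other times after dosing.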